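The compounds below may be only part of what the source reports. "The series", "measured", "known", "first", "only" and "open" are said of these compounds alone.

Of the compounds shown here, three sharing one core have been measured in an ADME assay on L929 cells (Mus musculus) for cytotoxicity; a higher number here means that more compound is tolerated, a lower number that less compound is tolerated. Compound 1 `CN(C)CCn1c2ccc3ccccc3c2c2nc3ccccc3nc21` gives 49900 nM. Compound 2 `CCN(CC)CCn1c2ccc3ccccc3c2c2nc3ccccc3nc21` gives 180000 nM. For compound 3 `c1ccc2c(c1)ccc1c2c2nc3ccccc3nc2n1CCN1CCCCC1` the read-out is only a limit, > 221000 nM. Within this set, enlarging the amine gave a 3.6-fold higher number from compound 1 to compound 2 (0.56 log units; beyond the scatter) and an at least 4.4-fold higher number from compound 1 to compound 3 (0.64 log units; beyond the scatter), whereas an at least 1.2-fold higher number from compound 2 to compound 3 (0.08 log units; that floor lies within the scatter) is only a floor. Compound 3 therefore stands at the top of the numbers shown, resting on the limit of > 221000 nM in this assay, at which 1 of the 3 values shown sits, rather than on a value. Compound 4 `CC1CCCCN1CCn1c2ccc3ccccc3c2c2nc3ccccc3nc21` differs from compound 3 by methyl in place of hydrogen on a saturated ring carbon. Going by the values given here, no measured step is of this kind; the nearest are the exchanges among the amines, which raised the number by modest amounts or left it inside the scatter. The step expected from this change, a step that the limit leaves unreadable from compound 3 to compound 4, is small. Compound 4 is expected to give about 250000 nM in this assay, within 120000 nM to 500000 nM, and most likely again only as a limit.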

Compound 4, half-maximal cytotoxic concentration: 113000 nM
Estimate against measurement, compound 4: 2.2-fold (0.34 log units) above; the whole stated range lies above it.
By their numbers in this assay, from the lowest: compound 1; then compounds 4 and 2 (each within the scatter of the next). At a limit, above all of these: compound 3.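

Methyl in place of hydrogen on a saturated ring carbon, next to the ring nitrogen, is the only change shown that alters the piperidin-1-yl ring itself, and in this assay it gives an at least 1.9-fold lower number from compound 3 to compound 4 (0.29 log units; that floor lies within the scatter). Compound 3 stands only at a limit, so this step is a floor and its true size cannot be read: the limit of > 221000 nM in this assay, at which 1 of the 4 values shown sits.

Against diethylamino, the 2-methylpiperidin-1-yl group gives a 1.6-fold lower number from compound 2 to compound 4 (0.20 log units; within the scatter), so these two cannot be told apart, whereas against dimethylamino it gives a 2.3-fold higher number from compound 1 to compound 4 (0.35 log units; beyond the scatter).

On these data alone, whether methyl truly lowers the number from that of the unsubstituted ring stays open, since the floor lies within the scatter. Also open, as far as these compounds go, is how a morpholin-4-yl group, or a longer chain in place of the ethyl link, would read in this assay.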